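Adding bromo to compound 1 to give compound 3

The source may hold more compounds than are shown below. What is called first, only, known or untested is meant among the compounds shown, and "the series" means these compounds.

Measured compounds:
Compound 1 `O=C(NC(=S)Nc1ccc(Sc2ncccn2)cc1)c1ccccc1`: "not determined" (no result reported)
Compound 2 `O=C(NC(=O)c1ccccc1)Nc1ccc(Sc2ncc(Br)cn2)cc1`: 5000 nM

The measurements come from a functional assay on MIA PaCa-2 cells (Homo sapiens) for cytotoxicity, read by MTT assay; a lower number here means a stronger inhibitor, a higher number a weaker inhibitor. In this test, compound 1 has no number to its name: its entry reads "not determined" (no result reported), so it offers no starting value and its standing relative to compound 2 cannot be read. The next compound is compound 3 `O=C(NC(=S)Nc1ccc(Sc2ncc(Br)cn2)cc1)c1ccccc1`, which is derived from compound 1 by a single change on the ring with two nitrogens: bromo in place of hydrogen on an aromatic carbon. In words, bromo replaces hydrogen on an aromatic carbon, two atoms from the ring nitrogen and para to a large group, turning pyrimidin-2-yl into 5-bromopyrimidin-2-yl.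

With no value for compound 1, the size of this step cannot be measured. A modest gain in strength is expected, little beyond the usual scatter. The nearest anchor is compound 2, which also holds the 5-bromopyrimidin-2-yl group and gives 5000 nM. The expected value therefore sits in the same region, slightly on the stronger side. For compound 3 the estimated value is 3000 nM, with an expected range from 800 nM to 10000 nM.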

Compound 3, half-maximal inhibitory concentration: 10000 nM
Beside the measured number, compound 3's estimate is 3.3-fold (0.52 log units) below it; measured number inside the range.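

No step can be read from compound 1 to compound 3: in this assay compound 1 has the entry "not determined" (no result reported), so compound 3, at 10000 nM, has no starting value to be set against. The compounds shown leave open what bromo in place of hydrogen does to strength in this assay. No evidence bearing on this result is available.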